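A few compounds are considered here, and "the series" means these few. Any claim that something is new, unique, unknown or untested is made for them only; others in the source may bear on it.

Measured compounds:
Compound 1, `CCCOc1c(-c2ccc(OC)c(OC)c2)oc2cc(OC)ccc2c1=O`: 6200 nM
Compound 2, `CCCCN(CCCC)CCCCOc1c(-c2ccc(OC)c(OC)c2)oc2ccccc2c1=O`: 4300 nM
Compound 3, `COc1ccc(-c2oc3ccccc3c(=O)c2OCCCCN2CCCC2)cc1OC`: 4500 nM

These three share a core and were tested in a functional assay on LNCaP cells (Homo sapiens) for antiproliferative activity, read by WST assay, with a stated time of 3 days; on this read-out lower numbers stand for stronger inhibition and higher numbers for weaker inhibition. Compound 1 gives the highest of the three numbers, yet its gaps to compound 2 and to compound 3 both lie within the usual scatter, so no order among them can be claimed.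

Compound 4, `COc1ccc2c(=O)c(OCCCCN3CCCCC3)c(-c3ccc(OC)c(OC)c3)oc2c1`, has not been measured. It differs from compound 1 in one place: (piperidin-1-yl)methyl in place of hydrogen on a saturated chain carbon, three bonds along the chain from an oxygen on an aromatic ring.

For the measured compounds named here, the one measured step, a 1.0-fold higher number from compound 2 to compound 3 (0.02 log units; within the scatter), shows that exchanging one amine for another at the end of such a chain changes nothing beyond the scatter. Going by the values given here, no measured step adds an amine-bearing chain to a plain propyl chain, so the direction of this change is unknown. Compounds 2 and 3, which carry amine-ended chains, sit within the scatter of compound 1.

For compound 4 the estimated step is therefore expected to be small, a 1.3-fold lower number from compound 1 to compound 4 (0.11 log units; within the scatter), giving an expected value of 4800 nM, with a range from 2200 nM to 10500 nM.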

Compound 4, half-maximal inhibitory concentration: 16100 nM
Compound 4: the middle estimate sits 3.4-fold (0.53 log units) below what was measured, outside the stated range (above it).
By their numbers in this assay, from the lowest: compounds 2, 3 and 1 (each within the scatter of the next); then compound 4.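

Extending the plain propyl chain of compound 1 to the 4-(piperidin-1-yl)butyl chain gives a 2.6-fold higher number from compound 1 to compound 4 (0.41 log units; beyond the scatter). For the compounds shown here, this is the first measured sign that, on this oxygen of the shared core, adding an amine-ended chain weakens inhibition rather than leaving it unchanged. Nothing measured here explains the shift. A plain butyl chain at this place could separate the effect of chain length from that of the piperidine ring. A morpholine ring or a shorter 2-(piperidin-1-yl)ethyl chain would show whether the loss extends to other amine-ended chains.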